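Moving the hydroxy group from compound 2 to compound 3

The source may hold more compounds than are shown below. What is called first, only, known or untested is meant among the compounds shown, and "the series" means these compounds.

In a functional assay on MDA-MB-231 cells (Homo sapiens) for inhibition, read by sulforhodamine B assay, with a stated time of 48 h (a higher number here means a weaker inhibitor of growth, a lower number a stronger inhibitor of growth), compound 1 `O=C(Cc1csc2nc(-c3ccc(Br)cc3)cn12)N/N=C/c1ccccc1` gives 57500 nM and compound 2 `O=C(Cc1csc2nc(-c3ccc(Br)cc3)cn12)N/N=C/c1ccccc1O` gives 17000 nM, the lower of the two numbers. Compound 3 `O=C(Cc1csc2nc(-c3ccc(Br)cc3)cn12)N/N=C/c1ccc(O)cc1` has the same atoms as compound 2, joined differently: 4-hydroxyphenyl in place of 2-hydroxyphenyl on a carbon with a double bond to nitrogen. Going by the values given here, the only measured step that bears on this is a 3.4-fold lower number from compound 1 to compound 2 (0.53 log units; beyond the scatter), where hydroxy replaced hydrogen on an aromatic carbon. Among the compounds with values here, no measured step moves that group, so only a small shift towards a higher number is expected, a 1.5-fold higher number from compound 2 to compound 3 (0.18 log units; within the scatter). For compound 3 the estimated value is 26000 nM, with an expected range from 10000 nM to 60000 nM.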

Compound 3, concentration for total growth inhibition: 43700 nM
The estimate for compound 3 lay 1.7-fold (0.23 log units) below the measured number; low and high end bracket the measured number.
By their numbers in this assay, from the lowest: compound 2; then compounds 3 and 1 (each within the scatter of the next).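

In this assay, where the hydroxy group sits on the ring makes a real difference: 4-hydroxyphenyl in place of 2-hydroxyphenyl gives a 2.6-fold higher number from compound 2 to compound 3 (0.41 log units; beyond the scatter). The gain seen on adding hydroxy therefore holds for 2-hydroxyphenyl but not for 4-hydroxyphenyl, where the same addition gives a 1.3-fold lower number from compound 1 to compound 3 (0.12 log units; within the scatter). No measurement at hand accounts for this difference between the two groups. Still open, as far as these compounds go, is whether an amine or a methoxy group in place of the hydroxy of 2-hydroxyphenyl would keep the lower number of compound 2.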